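The source may report more compounds than this note shows. Statements on the series, on what has been measured and on what is new or still open speak of the compounds shown alone.

Measured compounds:
compound 1 `O=C1O[C@H]([C@@H](O)Cn2cc(-c3cc(C(F)(F)F)cc(C(F)(F)F)c3)nn2)C(OCc2ccccc2)=C1OCc1ccccc1` gives 33800 nM
compound 2 `O=C1O[C@H]([C@@H](O)Cn2cc(C3CC3)nn2)C(OCc2ccccc2)=C1OCc1ccccc1` gives 38100 nM
compound 3 `O=C1O/C(=C\Cn2cc(-c3cccc(O)c3)nn2)C(OCc2ccccc2)=C1OCc1ccccc1` gives 61700 nM

In a functional assay on HepG2 cells (Homo sapiens) for antiproliferative activity, read by MTT assay, with a stated time of 72 h (a higher number here means a weaker inhibitor, a lower number a stronger inhibitor), compound 2 gives 38100 nM, the second highest of the three numbers. Its nearest neighbour is compound 1, whose value in this assay is 33800 nM; the furthest is compound 3 with 61700 nM. Both gaps lie within the scatter of the assay, so the three compounds cannot be told apart on these numbers.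

Compound 4 `COc1ccc(-c2cn(C[C@H](O)[C@H]3OC(=O)C(OCc4ccccc4)=C3OCc3ccccc3)nn2)cc1` is not yet measured. It differs from compound 2 in one place: 4-methoxyphenyl in place of cyclopropyl on an aromatic carbon. For the measured compounds named here, no step between measured compounds shows what this kind of exchange does. Compound 1, which carries a six-membered aromatic ring at the same place, sits within the scatter of compound 2, and compound 3, with a different aromatic ring on another core, does so too. The step from compound 2 to compound 4 is therefore expected to stay within the scatter, with no clear direction, as a 1.1-fold lower number from compound 2 to compound 4 (0.02 log units; within the scatter). Compound 4 is estimated to give 36000 nM in this assay, expected to fall between 15000 nM and 85000 nM.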

Compound 4, half-maximal inhibitory concentration: 46400 nM
For compound 4 the middle estimate is 1.3-fold (0.11 log units) below the measured one, and the stated range covers the measured number.
By their numbers in this assay, from the lowest: compounds 1, 2, 4 and 3 (each within the scatter of the next).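

The position on the aromatic carbon of the five-membered aromatic ring with 3 nitrogen now has its first direct one-place exchange: in this assay, putting 4-methoxyphenyl in place of cyclopropyl gives a 1.2-fold higher number from compound 2 to compound 4 (0.09 log units; within the scatter) on the shared core. For the compounds shown here, exchanging a three-membered non-aromatic ring for a six-membered aromatic ring that brings a hydrogen-bond acceptor therefore leaves the number within the scatter here, which the earlier compounds could not show without a step between them. Nothing else measured bears on this result.

As far as these compounds go, whether an amine, a carboxylic acid or a longer alkyl chain at this position would move the number beyond the scatter remains open. The compounds shown also leave open whether the same exchange would behave alike on the core of compound 3.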